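This account rests on a few compounds, and the source may have more. Where it says the series, first, only, none or still open, it means among the compounds named here.

In a functional assay on HeLa cells (Homo sapiens) for antiproliferative activity, read by MTT assay, with a stated time of 24 h (on this read-out lower numbers stand for stronger inhibition and higher numbers for weaker inhibition), compound 1 `Cc1ccc(-c2nn(-c3ccccc3)cc2-c2nc3ccccc3n2S(=O)(=O)c2ccc(F)cc2)cc1` gives 3670 nM and compound 2 `O=S(=O)(c1ccccc1)n1c(-c2cn(-c3ccccc3)nc2-c2ccc(C(F)(F)F)cc2)nc2ccccc21` gives 560 nM as the lower of the two numbers, a gap beyond the scatter. Compound 3 `O=S(=O)(c1ccc(F)cc1)n1c(-c2cn(-c3ccccc3)nc2-c2ccc(C(F)(F)F)cc2)nc2ccccc21` awaits measurement. Going by the values given here, its one difference from compound 2 is fluoro in place of hydrogen on an aromatic carbon and amounts to phenylsulfonyl becoming (4-fluorophenyl)sulfonyl, with fluoro in place of hydrogen on an aromatic carbon. Among the compounds with values here, no measured pair shows this change alone, and in this assay no step beyond the scatter is expected. The estimated step is a 1.1-fold higher number from compound 2 to compound 3 (0.04 log units; within the scatter) in size. Compound 3 is expected at 620 nM with an estimated range from 260 nM to 1500 nM for now.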

Compound 3, half-maximal inhibitory concentration: 2190 nM
Beside the measured number, compound 3's estimate is 3.5-fold (0.55 log units) below it, outside the stated range (above it).
By their numbers in this assay, from the lowest: compound 2; then compounds 3 and 1 (each within the scatter of the next).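

In this assay, the change from phenylsulfonyl to (4-fluorophenyl)sulfonyl is not neutral at this position, giving a 3.9-fold higher number from compound 2 to compound 3 (0.59 log units; beyond the scatter) as the step. With (4-fluorophenyl)sulfonyl held fixed, trifluoromethyl in place of methyl gives a 1.7-fold lower number from compound 1 to compound 3 (0.22 log units; within the scatter) as its step, so that swap makes no difference beyond the scatter here. Nothing measured here accounts for the fluoro step. As far as these compounds go, whether an amine or methoxy in place of the fluoro would give a number closer to that of compound 2 or of compound 3 remains open. So does whether the fluoro step keeps its size with methyl in place of trifluoromethyl.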